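Chalcone-pyrazole series: difluoro analogue of the dichloro compound

The source may hold more compounds than are shown below. What is called first, only, known or untested is meant among the compounds shown, and "the series" means these compounds.

So far, three members of the series have been measured in a functional assay on ACHN cells (Homo sapiens) for inhibition, read by sulforhodamine B assay, with a stated time of 48 h; on this read-out lower numbers stand for stronger inhibition of growth and higher numbers for weaker inhibition of growth. Compound 1 `COc1ccc(-c2cc(/C=C/C(=O)c3ccc(N)cc3)[nH]n2)cc1` gives 10600 nM. Compound 3 `COc1ccc(C(=O)/C=C/c2cc(-c3cc(OC)c(OC)c(OC)c3)n[nH]2)cc1OC` gives 3090 nM. For compound 2 `COc1cc(-c2cc(/C=C/C(=O)c3ccc(Cl)c(Cl)c3)[nH]n2)cc(OC)c1OC` this assay reports only a limit, > 100000 nM, so compound 2 stands at the weak end of the numbers shown, without a point value of its own; the one measured step that leaves it is an at least 32-fold lower number from compound 2 to compound 3 (1.51 log units; beyond the scatter), which is therefore itself only a lower bound on the change.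

Compound 4 `COc1cc(-c2cc(/C=C/C(=O)c3ccc(F)c(F)c3)[nH]n2)cc(OC)c1OC` differs from compound 2 by 3,4-difluorophenyl in place of 3,4-dichlorophenyl on a carbonyl carbon. Among the compounds with values here, no measured step bears directly on this exchange; the only step from compound 2 replaces the 3,4-dichlorophenyl with 3,4-dimethoxyphenyl, a different group altogether, so its size says nothing certain about 3,4-difluorophenyl. Because compound 2 sits at the limit of > 100000 nM in this assay, at which 1 of the 3 values shown sits, any real change in this assay could be hidden, and a further limit for compound 4 is plausible.

Compound 4 is therefore expected to come out near compound 2, the step being an expected at least 1.2-fold lower number from compound 2 to compound 4 (0.09 log units; that floor lies within the scatter), with no clear direction beyond the scatter. The estimate for compound 4 in this assay is 80000 nM, within a range of 20000 nM to 300000 nM.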

Compound 4, concentration for total growth inhibition: > 100000 nM
Compound 4 gave a limit, no number; the forecaster's own chance of this, stated with the estimate: 55%; middle value at least 1.2-fold (0.09 log units) from the limit.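

In this assay compound 4 gives > 100000 nM, which is a limit and not a number. On a carbonyl carbon, 3,4-difluorophenyl in place of 3,4-dimethoxyphenyl gives an at least 32-fold higher number from compound 3 to compound 4 (1.51 log units; beyond the scatter), a lower bound on the change, so the large gap first seen with 3,4-dichlorophenyl is not confined to that one group and now holds for two halogen-bearing phenyl groups at this position. The step between the two halogen-bearing compounds cannot be read, and no order between 3,4-dichlorophenyl and 3,4-difluorophenyl can be stated, with compound 2 and compound 4 both at the same limit: the limit of > 100000 nM in this assay, at which 2 of the 4 values shown sit.

The compounds shown do not tell whether any halogen-bearing phenyl group at this position would give a measurable number in this series, or whether the two methoxy groups of compound 3 are both needed for the lower number it shows. A phenyl group on the carbonyl carbon carrying a hydroxyl or a carboxylic acid, with the rest of the core of compound 3 unchanged, would test how far this position tolerates other groups.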